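Extending the ethyl chain of compound 2 by one carbon

The source may hold more compounds than are shown below. What is called first, only, known or untested is meant among the compounds shown, and "the series" means these compounds.

- Compound 1 `O=C(NO)c1ccc(COc2ccccc2)cc1` gives "not determined" (no result reported)
- Compound 2 `CCc1ccc(OCc2ccc(C(=O)Nc3ccccc3N)cc2)cc1` gives 5880 nM

Among the compounds with values here, in a functional assay on MGC-803 cells (Homo sapiens) for antiproliferative activity, read by CCK-8 assay, with a stated time of 72 h (on this read-out higher numbers stand for weaker inhibition and lower numbers for stronger inhibition), compound 2 gives 5880 nM, the only number available so far. No result is reported for compound 1, so compound 2 cannot yet be ranked against anything and no trend can be drawn.

The next compound is compound 3 `CCCc1ccc(OCc2ccc(C(=O)Nc3ccccc3N)cc2)cc1`. It differs from compound 2 by methyl in place of hydrogen on a saturated chain carbon, two bonds along the chain from an aromatic carbon. Put another way, 4-ethylphenyl becomes 4-propylphenyl, and the rest of the structure is unchanged.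

Within the data shown here, no pair of measured compounds shows what a change of this kind does in this assay, so the size of the step has to be assumed. The expectation is no step beyond the usual scatter, in either direction, with compound 2 at 5880 nM as the sole anchor. The expected outcome is a 1.1-fold lower number from compound 2 to compound 3 (0.03 log units; within the scatter) and this remains a weakly supported estimate. Compound 3 is estimated at 5500 nM, with an expected range of 2000 nM to 13000 nM.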

Compound 3, half-maximal inhibitory concentration: 4420 nM
Estimate against measurement, compound 3: 1.2-fold (0.09 log units) above, and the stated range covers the measured number.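

Extending 4-ethylphenyl to 4-propylphenyl gives the first readable step in the series: in this assay it is a 1.3-fold lower number from compound 2 to compound 3 (0.12 log units; within the scatter), so compound 2 and compound 3 sit at one level on this read-out. This position, on a saturated chain carbon two bonds along the chain from an aromatic carbon, therefore accepts the added methyl without a change that can be told from the scatter, though this rests on a single pair. Nothing measured here accounts for the result or gives a cause for it.

A single step cannot show whether this flat response continues with a longer chain such as butyl, or what a branched isopropyl group, or an amine or a carboxylic acid at the end of the chain, would do at this position. Within the data shown here, no step involving compound 1 can be read, as it has no number, so the effect of the group at the other end of the molecule also stays open.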